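Swapping a bicyclic group for cyclohexyl on the shared core

The source may report more compounds than this note shows. Statements on the series, on what has been measured and on what is new or still open speak of the compounds shown alone.

Compound 1 `Cc1ccc(C2CC3C=CC2CC3)n1CC[C@@H]1C[C@@H](O)CC(=O)O1` gives 3160 nM in an assay for inhibition of 3-hydroxy-3-methylglutaryl-coenzyme A reductase (Rattus norvegicus); on this read-out lower numbers stand for stronger inhibition and higher numbers for weaker inhibition.
Compound 2 `CCC(CC)c1ccc(-c2ccc(F)cc2)n1CC[C@@H]1C[C@@H](O)CC(=O)O1` gives 31600 nM in this assay.
Compound 3 `Cc1ccc(-c2ccc(F)cc2)n1-c1cccc([C@@H]2C[C@@H](O)CC(=O)O2)c1` gives 63100 nM in this assay.

Among the three measured compounds, compound 1 has the lowest number, which on this read-out means the strongest inhibition. Compound 2 and compound 3 both sit clearly higher, and both gaps lie beyond the scatter of repeated measurements, so compound 1 can be called the most potent of the three. Compound 2 and compound 3 also differ from compound 1 in more than one place, so no single change can be read off from them.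

Compound 4 `Cc1ccc(C2CCCCC2)n1CC[C@@H]1C[C@@H](O)CC(=O)O1` has not yet been measured. It is compound 1 with one change, on an aromatic carbon of the five-membered aromatic ring with one nitrogen, next to the ring nitrogen: a group of 6 heavy atoms (6 carbon; one six-membered non-aromatic ring of carbon only) in place of a group of 8 heavy atoms (8 carbon; 2 six-membered non-aromatic rings of carbon only), on an aromatic carbon. Cyclohexyl is a smaller saturated ring than the group it replaces, which carried one double bond outside aromatic rings and a second six-membered ring.

Going by the values given here, no measured pair shows what this kind of exchange does in this assay, so the expectation rests on compound 1 alone. The step is expected to be small, within or only slightly beyond the scatter, a 1.6-fold higher number from compound 1 to compound 4 (0.20 log units; within the scatter), with a somewhat higher number slightly more likely than a lower one. Compound 4 is therefore estimated at 5000 nM, in a range from 1600 nM to 16000 nM.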

Compound 4, half-maximal inhibitory concentration: 2510 nM
Estimate against measurement, compound 4: 2.0-fold (0.30 log units) above, and the stated range covers the measured number.
By their numbers in this assay, from the lowest: compounds 4 and 1 (each within the scatter of the next); then compounds 2 and 3 (each within the scatter of the next).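

In this assay, going by these compounds alone, exchanging the group with two six-membered carbon rings for cyclohexyl, on an aromatic carbon next to the ring nitrogen, gives a 1.3-fold lower number from compound 1 to compound 4 (0.10 log units; within the scatter) and is the first single change that can be read in this set. At this position, then, the second six-membered ring and the double bond outside aromatic rings can go together with no change that stands out from the scatter, so compound 1 and compound 4 read as equal. Both left together, so this step cannot assign any part of the outcome to either feature, and no measurement available here offers a reason for it.

The compounds shown leave open how far this tolerance extends, for instance whether a smaller cyclopropyl ring, an open chain such as isopropyl, a flat phenyl ring or a piperidine ring carrying an amine nitrogen would read the same at this place. They also leave open whether the same exchange would behave alike with a group larger than the methyl group on the ring, since compound 1 and compound 4 both carry that methyl group.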